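The source may hold more compounds than are shown below. What is called first, only, known or untested is meant among the compounds shown, and "the series" means these compounds.

Working notes on the series, followed here in an ADME assay on Huh7.5.1 cells (Homo sapiens) for cytotoxicity, read by ATP content, with a stated time of 48 h; on this read-out higher numbers stand for lower toxicity in this test and lower numbers for higher toxicity in this test. Compound 1 `Cc1ccccc1-c1nc(CN2CCC(C(=O)NCCCN3CCC(C(C)C)CC3)CC2)c(C)o1` gives 4280 nM in this assay. Compound 2 `Cc1oc(-c2c(Br)cccc2Br)nc1CN1CCC(C(=O)NCCCN2C[C@H](C)C[C@H](C)C2)CC1` gives 6500 nM in this assay; the two numbers lie within the scatter of each other, so no ordering of compound 2 against compound 1 can be read from them, and compound 2 simply stands alongside compound 1 on this read-out. Compound 3 `Cc1ccc(-c2nc(CN3CCC(C(=O)NCCCN4C[C@H](C)C[C@H](C)C4)CC3)c(C)o2)c(C)c1` has not been measured. It differs from compound 2 at a single place: 2,4-dimethylphenyl in place of 2,6-dibromophenyl on an aromatic carbon. Within the data shown here, no measured pair changes this group alone, so there is no step from which the size of the effect could be read; the only comparison at hand, compound 1 against compound 2, alters two parts of the molecule at once and stays within the scatter. The step expected here is a 1.2-fold lower number from compound 2 to compound 3 (0.07 log units; within the scatter), nothing beyond the scatter. For compound 3 the estimate in this assay is 5500 nM, expected to fall between 2500 nM and 12000 nM.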

Compound 3, half-maximal cytotoxic concentration: 4110 nM
Compound 3: the middle estimate sits 1.3-fold (0.13 log units) above what was measured; the measured number falls inside the stated range.
By their numbers in this assay, from the lowest: compounds 3, 1 and 2 (each within the scatter of the next).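

In this assay, among these compounds, a 1.6-fold lower number from compound 2 to compound 3 (0.20 log units; within the scatter) is the first step that isolates this change, with 2,4-dimethylphenyl in place of 2,6-dibromophenyl on the aromatic carbon next to the ring nitrogen and next to the ring oxygen. On this read-out the two groups cannot be told apart at this position, although one carries bromine and the other is carbon only, and neither has hydrogen-bond donors or acceptors. Nothing measured on these compounds offers an explanation for this result.

Going by these compounds, it remains open whether a group of another kind on this aromatic carbon, such as a phenyl bearing a carboxylic acid or an amine, would give a step beyond the scatter, since a single pair of closely matched groups says little about the range of the position. Compound 1 differs from compound 2 and from compound 3 in more than one place, so the contribution of each of its differences cannot be read, and the part of the molecule beyond the amide remains without a step of its own.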